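The compounds below may be only part of what the source reports. "The series", "measured", "known", "first", "only" and "open" are said of these compounds alone.

Measured so far in an assay on isolated protein for displacement of a labelled ligand from metabotropic glutamate receptor 5 (Homo sapiens), with a stated time of 60 min, tested at 1 uM; on this read-out lower numbers stand for less inhibition and higher numbers for more inhibition at the one concentration tested (going by the name of the read-out):
compound 1 `CC1CCN(c2c(S(=O)(=O)c3ccc(F)c(Cl)c3)cnc3cc(Cl)ccc23)CC1` — 94%
compound 2 `CC1CCN(c2c(S(=O)(=O)c3ccc(F)cc3)cnc3ccc(Cl)cc23)CC1` — 89%
compound 3 `CC1CCN(c2c(S(=O)(=O)c3ccc(F)c(Cl)c3)cnc3cc(F)ccc23)CC1` — 94%

Compound 1 stands level with compound 3 at the digits shown, the two together at the top of the three numbers; compound 2 sits lower by an amount that is still within the scatter. Going by the values given here, the one step measured, no change at the digits printed from compound 1 to compound 3 (within the scatter), did not move the read-out.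

Compound 4 `CC1CCN(c2c(S(=O)(=O)c3cc(F)cc(F)c3)cnc3cc(Cl)ccc23)CC1` is not yet measured. Relative to compound 1 the change is 3,5-difluorophenyl in place of 3-chloro-4-fluorophenyl on a sulfonyl sulfur. Among the compounds with values here, no measured step touches this aryl group on the sulfonyl sulfur; the step of no change at the digits printed from compound 1 to compound 3 (within the scatter) concerns a halogen on the shared core and bears only indirectly, showing that one halogen swap elsewhere left the read-out unchanged. Compound 2, which carries a mono-fluorinated aryl on the sulfonyl sulfur together with a different core substitution, gives 89%, within the scatter of compound 1. For compound 4 the expected step is therefore a number 6 percentage points lower from compound 1 to compound 4 (within the scatter), at most a small drop that is within the scatter. The estimate for compound 4 in this assay is 88%, expected to lie between 74% and 97%.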

Compound 4, a percentage reported as inhibition, at one concentration (the size of the read-out at that concentration, not a potency): 94%
For compound 4 the middle estimate is 6 percentage points below the measured one; the range from low to high includes it.
By their numbers in this assay, from the lowest: compounds 2, 1, 3 and 4 (each within the scatter of the next).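

In this assay, going by these compounds alone, this is the first direct reading on the aryl group on the sulfonyl sulfur: 3,5-difluorophenyl in place of 3-chloro-4-fluorophenyl gives no change at the digits printed from compound 1 to compound 4 (within the scatter). The earlier step touched only a halogen on the shared core, whereas this one shows that the position takes an exchange of chlorine for a second fluorine, with the fluorines placed differently, and leaves the read-out unmoved. No supporting data bear on why this is so.

Still open, from the compounds shown here alone, is whether an unsubstituted phenyl, or a methoxy or nitrile group on this aryl ring, would hold the read-out. With a single concentration, any potency differences among these compounds also remain open.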